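The source may report more compounds than this note shows. Statements on the series, on what has been measured and on what is new or still open speak of the compounds shown alone.

Compound 1 `CCCCOc1cccc(C2CNC(=O)C2)c1` in an assay on isolated protein for inhibition of phosphodiesterase 1 (Bos taurus), read by cGMP accumulation, in the presence of a further agent that is not named here (a lower number here means a stronger inhibitor, a higher number a weaker inhibitor), gives > 1000000 nM, a limit of the assay.
Compound 2 `CCCCOc1cc(C2CNC(=O)C2)ccc1OC` gives > 1000000 nM, also a limit.
Compound 3 `COc1ccc(C2CNC(=O)C2)cc1OCC(C)C` gives > 1000000 nM, again a limit.

All three values sit at the limit (the limit of > 1000000 nM in this assay, at which 3 of the 3 values shown sit), so compound 3 stands there without a number of its own. Compound 4 `COc1ccc(C2CNC(=O)C2)cc1OCCCC(=O)O` differs from compound 3 by 2-carboxyethyl in place of isopropyl on a saturated chain carbon bound to an oxygen on an aromatic ring. The measured steps a step that the two limits leave unreadable from compound 1 to compound 2 and a step that the two limits leave unreadable from compound 2 to compound 3 are both unreadable, each running from one limit to another, so neither offers a size to carry over. The step of a number no higher from compound 3 to compound 4 (the limit leaves the size open) is thus expected to be unreadable as well. In this assay compound 4 is expected to remain at the limit, with an estimate of 1000000 nM and a range from 300000 nM to 3000000 nM.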

Compound 4, half-maximal inhibitory concentration: > 1000000 nM
Compound 4: only a limit was reported (the forecaster's own chance of this, stated with the estimate: 85%); the middle value lies on the limit itself.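

The steps from compound 2 and from compound 3 to compound 4 cannot be read, since each runs from one limit to another: the limit of > 1000000 nM in this assay, at which 4 of the 4 values shown sit. The compounds shown leave open how strongly any of them inhibits in this assay at all.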